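Bromination steps in a fused lactam series

The source may hold more compounds than are shown below. What is called first, only, known or untested is meant among the compounds shown, and "the series" means these compounds.

Measured so far:
Compound 1 `COC(=O)Cc1c[nH]c(=O)c2ccc(Br)n12` gives 176000 nM in a functional assay on PC-3 cells (Homo sapiens) for cytotoxicity, read by CCK-8 assay, with a stated time of 72 h; a higher number here means a weaker inhibitor, a lower number a stronger inhibitor.
Compound 2 `COC(=O)Cc1c[nH]c(=O)c2cc(Br)c(Br)n12` reaches only a limit of the assay, > 200000 nM.
Compound 3 `COC(=O)CC1CNC(=O)c2cccn21` likewise reaches only a limit of the assay, > 200000 nM.

The step from compound 1 to compound 2, (bromo in place of hydrogen on an aromatic carbon), is an at least 1.1-fold higher number from compound 1 to compound 2 (0.05 log units; that floor lies within the scatter); its floor character comes from the limit of > 200000 nM in this assay, at which 2 of the 3 values shown sit. How the core of compound 3 differs from the core of compound 1 is not broken down here.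

Compound 4 `COC(=O)CC1CNC(=O)c2ccc(Br)n21` has not been measured. It differs from compound 3 by bromo in place of hydrogen on an aromatic carbon. This is the same kind of change as from compound 1 to compound 2, but the place is not the same: in compound 4 the bromo enters next to the ring nitrogen and next to the ring atom that bears a fused ring, whereas in compound 2 it enters next to the ring atom that bears a bromo group, two ring bonds from the ring nitrogen.

Since compound 3 already sits at the limit > 200000 nM, the expected step that the limit leaves unreadable from compound 3 to compound 4 is set beside an at least 1.1-fold higher number from compound 1 to compound 2 (0.05 log units; that floor lies within the scatter): a weak effect, most likely leaving compound 4 at or beyond the limit as well. Compound 4 is estimated at 250000 nM, expected between 120000 nM and 500000 nM.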

Compound 4, half-maximal inhibitory concentration: 70000 nM
The estimate for compound 4 lay 3.6-fold (0.55 log units) above the measured number; the measured number lies below the stated range.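

In this assay, bromo in place of hydrogen on an aromatic carbon gives an at least 2.8-fold lower number from compound 3 to compound 4 (0.45 log units; beyond the scatter), so this change does not carry over as one fixed step from core to core: the same change on two cores in this assay, an at least 1.1-fold higher number (0.05 log units; that floor lies within the scatter) from compound 1 to compound 2 and an at least 2.8-fold lower number (0.45 log units; beyond the scatter) from compound 3 to compound 4, at least 3.2-fold (0.51 log units) apart, beyond the scatter of two such steps

This does not show that the core alone sets the outcome, since the bromo enters at a different place in the two steps, and in compound 2 it joins a bromo group already present, whereas compound 4 carries only one. Both steps rest on a value that is a limit, so they give bounds and not sizes: the limit of > 200000 nM in this assay, at which 2 of the 4 values shown sit.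

Going by these compounds, it remains open whether chloro or methyl at the place taken by bromo in compound 4, next to the ring nitrogen, would give a similar result. On these data alone, it also remains open whether the methyl ester side chain contributes, which a carboxylic acid or a primary amide in its place on compound 4 would address.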